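Phenyl in place of thiophen-2-yl on a weak core

The source may report more compounds than this note shows. Statements on the series, on what has been measured and on what is new or still open speak of the compounds shown alone.

Measured so far:
compound 1 `Cn1cccc1-c1cc(-c2cccs2)[nH]c(=O)c1C#N` in a functional assay on HOP-62 cells (Homo sapiens) for inhibition, read by sulforhodamine B assay, with a stated time of 48 h (on this read-out higher numbers stand for weaker inhibition of growth and lower numbers for stronger inhibition of growth), gives 83200 nM
compound 2 `CC1CCCc2c1[nH]c(=O)c(C#N)c2-c1cccn1C` gives a limit, > 100000 nM
compound 3 `COc1ccc(-c2cc(-c3cccn3C)c(C#N)c(N)n2)cc1OC` gives a limit, > 100000 nM

Within the data shown here, compound 1 is the only compound with a measured concentration in this assay, and that concentration is far from strong inhibition. The value of compound 2 is a limit of the assay. The value of compound 3 is likewise a limit, namely (the limit of > 100000 nM in this assay, at which 2 of the 3 values shown sit). Compound 4 `Cn1cccc1-c1cc(-c2ccccc2)[nH]c(=O)c1C#N` carries phenyl in place of thiophen-2-yl on an aromatic carbon. Among the measured compounds shown here, no step between measured compounds exists to size this change. The step of a 1.1-fold higher number from compound 1 to compound 4 (0.03 log units; within the scatter) is expected to stay within the usual scatter, in no set direction. Compound 4 is therefore estimated at 90000 nM, with a range from 30000 nM to 250000 nM, and it may well be reported only as a limit.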

Compound 4, concentration for 50% growth inhibition: > 100000 nM
Compound 4 was reported as a limit (the forecaster's own chance of this, stated with the estimate: 45%); middle value at least 1.1-fold (0.04 log units) away from the limit.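

Phenyl in place of thiophen-2-yl on the aromatic carbon next to the ring nitrogen gives an at least 1.2-fold higher number from compound 1 to compound 4 (0.07 log units; that floor lies within the scatter) in this assay. The value of compound 4 is a limit, so the real size of this step cannot be read. Neither of these two aromatic rings at this position gives strong inhibition, and the series now sits mostly at one ceiling: the limit of > 100000 nM in this assay, at which 3 of the 4 values shown sit.

Going by these compounds, whether an amine or a carboxylic acid at this position would give a measured value stays open. No step shown changes the 1-methyl-1H-pyrrol-2-yl group alone, so its part also remains unknown.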